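Compound 2 to compound 4: a step at the limit

This account rests on a few compounds, and the source may have more. Where it says the series, first, only, none or still open, it means among the compounds named here.

compound 1 `CCOc1ccc(C(=O)NNc2c(Br)cccc2Br)cc1`: > 100000 nM (a limit)
compound 2 `CCc1ccc(C(=O)NNc2c(Br)cccc2Br)cc1`: > 100000 nM (a limit)
compound 3 `COc1ccccc1C(=O)NNc1c(Br)cccc1Br`: > 100000 nM (a limit)

Within the data shown here, the series so far comes down to one observation in a toxicity assay on MDCK cells (Canis lupus familiaris) for cytotoxicity, read by CCK-8 assay, with a stated time of 48 h; on this read-out lower numbers stand for higher toxicity in this test and higher numbers for lower toxicity in this test: the limit of > 100000 nM in this assay, at which 3 of the 3 values shown sit. Among the measured compounds shown here, no measured compound has yet given a number. Compound 2 gives only a limit, > 100000 nM, so it offers a bound as a starting point and no exact value.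

Compound 4 `COC(=O)c1ccc(C(=O)NNc2c(Br)cccc2Br)cc1` is still to be measured in this assay. It carries methoxycarbonyl in place of ethyl on an aromatic carbon, para to a large group: methoxycarbonyl in place of ethyl on an aromatic carbon.

For the measured compounds named here, the one measured step that bears on this change is a step that the two limits leave unreadable from compound 1 to compound 2. It also exchanges one group for another on an aromatic carbon, but its size cannot be read, and it therefore gives no size to carry over. Going by the values given here, compound 3 adds a further limit and no step.

With nothing but limits to go on, no step beyond the scatter is expected in this assay, and a further report as a limit is the likeliest outcome. The estimated step is a step that the limit leaves unreadable from compound 2 to compound 4. That expectation rests on (the limit of > 100000 nM in this assay, at which 3 of the 3 values shown sit). For compound 4 the estimated value is 150000 nM, with an expected range of 50000 nM to 400000 nM.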

Compound 4, half-maximal cytotoxic concentration: 87600 nM
Compound 4: middle estimate off by 1.7-fold (0.23 log units), on the high side; the measured number falls inside the stated range.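

In this assay, among these compounds, compound 4 is the first compound to give a number rather than a limit, which shows that the values at this aromatic carbon, para to a large group, are not all confined to the limit. Methoxycarbonyl in place of ethyl gives an at least 1.1-fold lower number from compound 2 to compound 4 (0.05 log units; that floor lies within the scatter), and methoxycarbonyl in place of ethoxy gives an at least 1.1-fold lower number from compound 1 to compound 4 (0.05 log units; that floor lies within the scatter); both are floors set by a limit on one side, so they fix a direction only as far as that floor allows and give no true size. The series as a whole still sits mainly at the limit: the limit of > 100000 nM in this assay, at which 3 of the 4 values shown sit.

Going by these compounds, how far the true values of compound 1 and compound 2 lie from the number of compound 4 stays open, and the step between compound 1 and compound 2 cannot be read. Also open, on these data alone, is whether an amine, a carboxylic acid or a longer ester chain in this same place would give a number clearly lower than that of compound 4, beyond the usual scatter of this read-out.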